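Acetamido-chlorophenyl urea in the bis(fluorophenyl) series

This account rests on a few compounds, and the source may have more. Where it says the series, first, only, none or still open, it means among the compounds named here.

Compound 2 `Nc1ccc(NC(=O)NCCCCC(c2ccc(F)cc2)c2ccc(F)cc2)cc1` carries the 4-aminophenyl on the urea nitrogen of the shared core. In a functional assay on MDA-MB-231 cells (Homo sapiens) for cytotoxicity, read by MTT assay, with a stated time of 48 h (a higher number here means a weaker inhibitor, a lower number a stronger inhibitor), compound 2 gives only a limit, > 20000 nM. That is the point at which (the limit of > 20000 nM in this assay, at which 1 of the 3 values shown sits), so compound 2 stands at the weak end of the three measured compounds without a number of its own. The other two give numbers: compound 1 `O=C(NCCCCC(c1ccc(F)cc1)c1ccc(F)cc1)Nc1ccc(Cl)cc1` gives 7680 nM in this assay, and compound 3 `O=C(NCCCCC(c1ccc(F)cc1)c1ccc(F)cc1)Nc1cccc([N+](=O)[O-])c1` gives 3790 nM in this assay.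

Compound 4 `CC(=O)Nc1cc(NC(=O)NCCCCC(c2ccc(F)cc2)c2ccc(F)cc2)ccc1Cl` is not yet measured. Its change from compound 2: 3-acetamido-4-chlorophenyl in place of 4-aminophenyl on an amide-type nitrogen.

Going by the values given here, two measured steps bear on this. First, an at least 2.6-fold higher number from compound 1 to compound 2 (0.41 log units; beyond the scatter); compound 4 returns a chloro to the ring, so that step is read in reverse. Second, an at least 5.2-fold lower number from compound 2 to compound 3 (0.72 log units; beyond the scatter), showing that leaving the 4-aminophenyl for another substituted phenyl brings the number down out of the limit. For comparison, a 2.0-fold lower number from compound 1 to compound 3 (0.31 log units; beyond the scatter).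

The expectation for compound 4 is therefore a lower number than compound 2 in this assay, roughly back to the level of compound 1, with the step of an at least 3.3-fold lower number from compound 2 to compound 4 (0.52 log units; beyond the scatter). The estimate for compound 4 is 6000 nM, with a range from 2500 nM to 15000 nM.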

Compound 4, half-maximal inhibitory concentration: 9120 nM
For compound 4 the middle estimate is 1.5-fold (0.18 log units) below the measured one; measured number inside the range.
By their numbers in this assay, from the lowest: compound 3; then compounds 1 and 4 (each within the scatter of the next). At a limit, above all of these: compound 2.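

In this assay, going by these compounds alone, the step to 3-acetamido-4-chlorophenyl on the amide-type nitrogen is an at least 2.1-fold lower number from compound 2 to compound 4 (0.34 log units; beyond the scatter) and so brings the series back from the limit, which shows that this nitrogen can carry a larger substituted phenyl than the earlier compounds did without losing a measurable number. Acetamido in place of hydrogen on an aromatic carbon gives a 1.2-fold higher number from compound 1 to compound 4 (0.07 log units; within the scatter) and thus adds no change beyond the scatter to the 4-chlorophenyl urea, whereas a 2.4-fold higher number from compound 3 to compound 4 (0.38 log units; beyond the scatter) leaves the 3-nitrophenyl with the lower number of this pair. The value of compound 2 is a limit and not a number: the limit of > 20000 nM in this assay, at which 1 of the 4 values shown sits.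

The compounds shown hold no phenyl with the acetamido alone, so the separate shares of the chloro and the acetamido in the step away from the 4-aminophenyl stay open. Also open, from the compounds shown here alone, are how a methoxy or a sulfonamide on this phenyl would read and whether a longer chain in the shared core would keep these numbers.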